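The source may hold more compounds than are shown below. What is called first, only, known or untested is meant among the compounds shown, and "the series" means these compounds.

Among the compounds with values here, compound 2, `O=C(O)Cc1sc(C(c2ccc(F)cc2)c2ccc(F)cc2)nc1-c1ccc(Cl)cc1`, is one of two compounds measured in an in vitro assay on HEK385-7 cells for displacement of a labelled ligand from prostaglandin D2 receptor 2 (Homo sapiens); a higher number here means a weaker inhibitor, a lower number a stronger inhibitor. In this assay compound 2 gives 9.7 nM, and its nearest neighbour compound 1, `O=C(O)Cc1sc(C(c2ccccc2)c2ccc(F)cc2)nc1-c1ccc(Cl)cc1`, gives 17 nM. Compound 2 stands lowest of these two numbers, but the step of a 1.8-fold lower number from compound 1 to compound 2 (0.24 log units; within the scatter) is within the scatter, so the two compounds cannot be separated on this evidence.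

Compound 3, `N#Cc1ccc(-c2nc(C(c3ccc(F)cc3)c3ccc(F)cc3)sc2CC(=O)O)cc1`, differs from compound 2 by cyano in place of chloro on an aromatic carbon, at a position para to a large group, so that the 4-chlorophenyl of compound 2 becomes a 4-cyanophenyl. Within the data shown here, no measured step touches this ring: the only step at hand, a 1.8-fold lower number from compound 1 to compound 2 (0.24 log units; within the scatter), concerns a fluoro for hydrogen exchange on a different ring and stayed within the scatter. The data therefore give no ground to expect a change beyond the scatter for compound 3 in this assay, and the estimate for compound 3 is 12 nM, with a range of 4 nM to 40 nM, which means an expected step of a 1.2-fold higher number from compound 2 to compound 3 (0.09 log units; within the scatter) and leaves open a true shift in either direction.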

Compound 3, half-maximal inhibitory concentration: 150 nM
Estimate against measurement, compound 3: 13-fold (1.10 log units) below; the measured number lies above the stated range.
By their numbers in this assay, from the lowest: compounds 2 and 1 (each within the scatter of the next); then compound 3.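

In this assay, the place held by chloro on the 4-chlorophenyl ring proves sensitive to substitution: cyano in place of chloro gives a 15-fold higher number from compound 2 to compound 3 (1.19 log units; beyond the scatter), the only step beyond the scatter among the compounds shown. The earlier step, a 1.8-fold lower number from compound 1 to compound 2 (0.24 log units; within the scatter), lay within the scatter and involved a different ring, so it gave no view of this position; the new result shows that a change here, para to a large group, can markedly weaken the inhibitor while leaving the rest of compound 2 intact. No available evidence accounts for this large step, and the data offer no measured property of either group that bears on it.

With only chloro and cyano compared at this position, the compounds shown leave open whether chloro is especially favourable or cyano especially unfavourable, a question that hydrogen, bromo, methyl or methoxy at the same place would help to settle. They also leave open whether an amine or a carboxylic acid would be tolerated there, and whether the same exchange would have a step of similar size on the core of compound 1.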